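Moving the Methyl Group: Compound 2 to Compound 3

The source may hold more compounds than are shown below. What is called first, only, known or untested is meant among the compounds shown, and "the series" means these compounds.

Compound 2 `COc1ccccc1N1CCN(CCCCC(=O)NCc2ccccc2-c2cccc(C)c2)CC1` is measured in an assay on CHO-K1 cells for displacement of a labelled ligand from 5-hydroxytryptamine receptor 7 (Homo sapiens), read by scintillation counting (on this read-out lower numbers stand for stronger inhibition and higher numbers for weaker inhibition), at 47.6 nM, the lowest of the two numbers recorded so far. Its nearest neighbour is compound 1 `COc1ccccc1N1CCN(CCCCC(=O)NCc2ccccc2-c2cccc(Cl)c2)CC1`, for which compound 1 gives 405 nM in this assay; the step of an 8.5-fold lower number from compound 1 to compound 2 (0.93 log units; beyond the scatter) is the only one known here. The untested compound 3 `COc1ccccc1N1CCN(CCCCC(=O)NCc2ccccc2-c2ccc(C)cc2)CC1` differs from compound 2 by a rearrangement of the same atoms: 4-methylphenyl in place of 3-methylphenyl on an aromatic carbon, at a place on an aromatic carbon of a six-membered aromatic ring of carbon only, ortho to a large group. Among the measured compounds shown here, the single measured step concerns a swap of chloro for methyl at one fixed position, not a move of the methyl itself, so it bears on this change only loosely and shows merely that substitution on this ring can matter. Compound 3 is therefore expected to give about 65 nM in this assay. This estimate corresponds to a step of a 1.4-fold higher number from compound 2 to compound 3 (0.14 log units; within the scatter). The expected range for compound 3 runs from 20 nM to 220 nM.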

Compound 3, inhibition constant: 66.1 nM
For compound 3 the middle estimate is 1.0-fold (0.01 log units) below the measured one, within the range that was stated.
By their numbers in this assay, from the lowest: compounds 2 and 3 (each within the scatter of the next); then compound 1.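

In this assay the step of a 1.4-fold higher number from compound 2 to compound 3 (0.14 log units; within the scatter) stays within the scatter, so 3-methylphenyl and 4-methylphenyl cannot be told apart at this place, on an aromatic carbon ortho to a large group. The step of a 6.1-fold lower number from compound 1 to compound 3 (0.79 log units; beyond the scatter) lies beyond the scatter, which shows that the gap first seen between the 3-chlorophenyl of compound 1 and the 3-methylphenyl of compound 2 also holds for 4-methylphenyl. No evidence is available that would explain this outcome.

The compounds shown compare chloro and methyl directly in one placement only, leaving open whether a 4-chlorophenyl group would stand as far from compound 3 as compound 1 stands from compound 2. They also leave open what an amine or a carboxylic acid on this ring would give.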